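Notes on aryl exchange at the biaryl position, imidazoline series

The source may report more compounds than this note shows. Statements on the series, on what has been measured and on what is new or still open speak of the compounds shown alone.

Measured so far:
Compound 1, `CC(Oc1ccccc1-c1ccccc1)C1=NCCS1`: in a functional assay on CHO cells for agonist activity at Alpha-2B adrenergic receptor (Homo sapiens) (a lower number here means a smaller maximal response, a higher number a larger maximal response), compound 1 gives a limit, < 0.3.
Compound 2, `CC(Nc1ccccc1-c1ccccc1)C1=NCCN1`: in this assay compound 2 gives 0.5.
Compound 3, `CC(Oc1ccccc1-c1cccnc1)C1=NCCN1`: in this assay compound 3 gives 0.5.

Compound 3 stands level with compound 2 at the digits shown, and the two lie within the scatter of each other. Going by the values given here, the remaining value in the set is the one for compound 1, which is a limit rather than a number, as noted in the limit of < 0.3 in this assay, at which 1 of the 3 values shown sits. Among the compounds with values here, no pair among the measured compounds differs in a single place, so no step between them can be read off.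

The unmeasured compound 4, `Cc1cccc(-c2ccccc2OC(C)C2=NCCN2)c1`, is reached from compound 3 by one change: 3-methylphenyl in place of pyridin-3-yl on an aromatic carbon. The imidazoline, the oxygen linker and the shared core are kept.

Within the data shown here, with only one measured compound carrying the pyridin-3-yl group, and no single-place comparison available, the step from compound 3 to compound 4 in this assay is expected to be small, and may not go beyond the scatter in either direction. Compound 4 is estimated at 0.45, with a range of 0.2 to 0.7. The estimate implies a step of a number 0.050 lower from compound 3 to compound 4 (within the scatter) from compound 3 to compound 4.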

Compound 4, intrinsic activity: the largest response reached, as a fraction of the reference agonist's: < 0.3
Compound 4: only a limit was reported (the forecaster's own chance of this, stated with the estimate: 25%); middle value at least 0.15 from the limit.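

Going by these compounds alone, this is the only single-place comparison in the set, and it shows that the aryl group at this position is not a neutral choice for maximal response. In this assay, placing 3-methylphenyl where pyridin-3-yl stood on an aromatic carbon, with everything else in the shared core kept, gives a number at least 0.20 lower from compound 3 to compound 4 (beyond the scatter). Compound 4 gives < 0.3, which is a limit and not a number, so the step has a bound but no exact size, and the set now holds two values of this kind: the limit of < 0.3 in this assay, at which 2 of the 4 values shown sit.

The change swaps a ring nitrogen for carbon and adds a methyl in the same move, so the compounds shown cannot say which of the two goes with the lower response, and a plain phenyl on the same oxygen-linked core would separate them. Also open, going by these compounds, is whether any other group at this place keeps the response of compound 3, such as an amine or a carboxylic acid on the ring, or a pyridin-4-yl in place of pyridin-3-yl.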